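The compounds below may be only part of what the source reports. "The series", "measured", "known", "first", "only" and "open" are said of these compounds alone.

In an ADME assay on HEK293 cells (Homo sapiens) for cytotoxicity, read by MTT assay, with a stated time of 44 h (on this read-out higher numbers stand for weaker inhibition and lower numbers for stronger inhibition), compound 3 `CCC1(c2cccc(Cl)c2)ON=C(c2ccc(Cl)cc2)O1` gives > 100000 nM, which is a limit of the assay rather than a measured number. Compound 1 `CCC1(c2cccc(Cl)c2)ON=C(c2ccccc2Cl)O1` gives > 100000 nM, likewise a limit. Compound 2 `Clc1ccc(C2=NOC(c3ccc(Cl)c(Cl)c3)O2)cc1` gives > 100000 nM, again a limit. The picture is summed up by the limit of > 100000 nM in this assay, at which 3 of the 3 values shown sit, so no compound here has yet shown a readable number. Going by the values given here, the one step that can be traced, a step that the two limits leave unreadable from compound 1 to compound 3, cannot be sized, since both ends sit at the limit.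

Compound 4 `Clc1ccc(C2=NOC(c3cccc(Cl)c3)O2)cc1` differs from compound 3 by hydrogen in place of ethyl on a saturated ring carbon. Among the compounds with values here, no measured step touches this change, and the only measured step is unreadable, so nothing points to a difference beyond the usual scatter. The step from compound 3 to compound 4 is therefore expected to be a number no higher from compound 3 to compound 4 (the limit leaves the size open), in no clear direction. Compound 4 is estimated to give 100000 nM, with a range from 30000 nM to 300000 nM, most likely reported once more as a limit.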

Compound 4, half-maximal inhibitory concentration: > 100000 nM
Compound 4: a limit, no number; the forecaster's own chance of this, stated with the estimate: 85%; the middle value sits exactly at the limit.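

Compound 4 also gives only a limit, not a number, so its steps from compound 2 and from compound 3 cannot be read: the limit of > 100000 nM in this assay, at which 4 of the 4 values shown sit. In this assay the compounds shown leave open whether any change to the shared core would give a readable number.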